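Removing a Fluorine From a Pyrrolidine-Bearing Purine Analogue

The source may report more compounds than this note shows. Statements on the series, on what has been measured and on what is new or still open speak of the compounds shown alone.

Compound 1, `CN1CCN(c2ccc(Nc3ncc4nc(Nc5ccccc5)n([C@H]5CCN(S(C)(=O)=O)C5)c4n3)cc2)CC1`, gives 17 nM in a functional assay on HCC827 cells (Homo sapiens) for antiproliferative activity, read by MTT assay, with a stated time of 72 h; a higher number here means a weaker inhibitor, a lower number a stronger inhibitor. Compound 2, `CN1CCN(c2ccc(Nc3ncc4nc(Nc5ccccc5)n([C@H]5CCN(S(=O)(=O)C6CC6)C5)c4n3)cc2)CC1`, gives 1.6 nM in this assay. Compound 3, `CNC(=O)CN1CC[C@H](n2c(Nc3ccc(F)cc3)nc3cnc(Nc4ccc(N5CCN(C)CC5)cc4)nc32)C1`, gives 1520 nM in this assay.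

Compound 3 stands highest of the three numbers, far weaker than both compounds 1 and 2. Compound 4, `CNC(=O)CN1CC[C@H](n2c(Nc3ccccc3)nc3cnc(Nc4ccc(N5CCN(C)CC5)cc4)nc32)C1`, differs from compound 3 only in hydrogen in place of fluoro on an aromatic carbon, the carbon being para to a large group. Among the measured compounds shown here, no measured pair changes this position: the one measured step, an 11-fold lower number from compound 1 to compound 2 (1.03 log units; beyond the scatter), concerns a substituent on a sulfonyl sulfur and says nothing about the fluorophenyl. With no guidance, the expected outcome for compound 4 is a step within the scatter, a 1.2-fold lower number from compound 3 to compound 4 (0.07 log units; within the scatter). Compound 4 is therefore estimated at 1300 nM, in the range 450 nM to 3800 nM.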

Compound 4, half-maximal inhibitory concentration: 170 nM
The estimate for compound 4 lay 7.6-fold (0.88 log units) above the measured number, outside the stated range (below it).
By their numbers in this assay, from the lowest: compound 2; then compound 1; then compound 4; then compound 3.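

Going from 4-fluorophenyl to phenyl gives an 8.9-fold lower number from compound 3 to compound 4 (0.95 log units; beyond the scatter) in this assay, so this position on the aromatic ring clearly matters, which the earlier compounds could not show. With phenyl now on both sides, the group on the ring nitrogen can also be compared: (methylcarbamoyl)methyl gives a 10-fold higher number from compound 1 to compound 4 (1.00 log units; beyond the scatter) and a 110-fold higher number from compound 2 to compound 4 (2.03 log units; beyond the scatter) when it replaces the two sulfonyl groups. Nothing available explains why removing the fluoro changes the number. The compounds shown leave open how a chlorine or a methoxy group on that carbon would compare, and whether fluoro has the same effect in the sulfonyl compounds.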